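This account rests on a few compounds, and the source may have more. Where it says the series, first, only, none or still open, it means among the compounds named here.

Compound 1, `Fc1ccc(C(SCCNC2CCN(Cc3ccccc3)CC2)c2ccc(F)cc2)cc1`, gives 32.9 nM in an assay on membranes from striatum (strain Sprague-Dawley) for displacement of a labelled ligand from sodium-dependent dopamine transporter (Rattus norvegicus), read by scintillation counting, with a stated time of 120 min; on this read-out lower numbers stand for stronger inhibition and higher numbers for weaker inhibition.
Compound 2, `Fc1ccc(C(SCCNC2CCN(Cc3ccc(Cl)cc3)CC2)c2ccc(F)cc2)cc1`, gives 39.6 nM in this assay.
Compound 3, `Fc1ccc(C(SCCNC2CCN(Cc3ccc(C(F)(F)F)cc3)CC2)c2ccc(F)cc2)cc1`, gives 190 nM in this assay.

Compound 3 has the highest of these three numbers and so is the weakest inhibitor of the three: the step of a 5.8-fold higher number from compound 1 to compound 3 (0.76 log units; beyond the scatter) and the step of a 4.8-fold higher number from compound 2 to compound 3 (0.68 log units; beyond the scatter) both lie beyond the scatter, whereas a 1.2-fold higher number from compound 1 to compound 2 (0.08 log units; within the scatter) does not. Compound 4, `O=C(c1ccccc1)N1CCC(NCCSC(c2ccc(F)cc2)c2ccc(F)cc2)CC1`, has not yet been measured in this assay. It differs from compound 3 by benzoyl in place of 4-(trifluoromethyl)benzyl on an amine nitrogen in a ring. Among the compounds with values here, two measured steps bear on this change in part: the trifluoromethyl that leaves here is the group whose arrival raised the number from compound 1 and from compound 2, so its removal alone would point back toward the numbers of those two compounds. Within the data shown here, no measured step covers the other part of the change, a benzoyl entering where a benzyl stood, so that part remains open. Compound 4 is therefore expected to give 90 nM, within a range from 20 nM to 400 nM. The expected step of a 2.1-fold lower number from compound 3 to compound 4 (0.32 log units; beyond the scatter) is a move toward a lower number, held with wide uncertainty.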

Compound 4, inhibition constant: 4.51 nM
For compound 4 the middle estimate is 20-fold (1.30 log units) above the measured one; the measured number lies below the stated range.
By their numbers in this assay, from the lowest: compound 4; then compounds 1 and 2 (each within the scatter of the next); then compound 3.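

Earlier compounds changed only the aromatic ring of the benzyl group, whereas compound 4 alters the group attached to the amine nitrogen in the ring. In this assay, benzoyl in place of benzyl gives a 7.3-fold lower number from compound 1 to compound 4 (0.86 log units; beyond the scatter) and so moves the number down, while the earlier changes at this position either left it within the scatter or raised it. Starting from the substituted benzyl groups, the same kind of change gives an 8.8-fold lower number from compound 2 to compound 4 (0.94 log units; beyond the scatter) and a 42-fold lower number from compound 3 to compound 4 (1.62 log units; beyond the scatter) on this read-out, and no measurement shown here offers a reason for any of these steps.

The compounds shown leave open whether a chloro or trifluoromethyl on the benzoyl ring would raise the number as it did, for trifluoromethyl, on the benzyl ring. They also leave open whether an acetyl, or a benzenesulfonyl in place of the benzoyl, would give a similarly low number.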